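This account rests on a few compounds, and the source may have more. Where it says the series, first, only, none or still open, it means among the compounds named here.

The series shares the core of compound 1 `O=C(c1ccc(NCc2ccc([N+](=O)[O-])cc2)c(Cl)c1)N1CCC(N2CCCCC2)CC1`, an aryl amide carrying a benzyl group with a nitro on a nitrogen on the aromatic ring. In an assay on HEK293 cells for inhibition of Leucine-rich repeat serine/threonine-protein kinase 2 variant G2019S (Homo sapiens), with a stated time of 15 min (a higher number here means a weaker inhibitor, a lower number a stronger inhibitor), compound 1 gives only a limit, > 1000 nM. Compound 2 `Cc1ccc(CNc2ccc(C(=O)N3CCC(N4CCCCC4)CC3)cc2Cl)cc1` carries a 4-methylbenzyl in place of that group. In this assay compound 2 likewise gives only a limit, > 1000 nM. The step that the two limits leave unreadable from compound 1 to compound 2 therefore cannot be sized, because of the limit of > 1000 nM in this assay, at which 2 of the 2 values shown sit. Compound 2 thus stands at the limit of this assay, with no numbered value in the series to set it against.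

Compound 3 `O=C(Nc1ccc(C(=O)N2CCC(N3CCCCC3)CC2)cc1Cl)c1ccc[nH]1` changes the same attachment: (1H-pyrrol-2-yl)carbonyl in place of 4-methylbenzyl on a nitrogen on an aromatic ring. Among the measured compounds shown here, no measured step involves an acyl group on that nitrogen; the only step recorded, methyl in place of nitro on an aromatic carbon, stays unreadable. The step that the limit leaves unreadable from compound 2 to compound 3 is therefore estimated from the two limits alone, with no clear direction and most likely within the scatter. Compound 3 is expected to give about 1500 nM in this assay, within 300 nM to 8000 nM, and a limit rather than a number is again quite possible.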

Compound 3, half-maximal inhibitory concentration: > 1000 nM
Compound 3 was reported as a limit; the forecaster's own chance of this, stated with the estimate: 60%; the middle value is on the limit's open side.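

In this assay compound 3 gives only a limit, > 1000 nM. Among the compounds shown here, no step among compound 1, compound 2 and compound 3 can be read, because all three values sit at the same limit: the limit of > 1000 nM in this assay, at which 3 of the 3 values shown sit. The compounds shown leave open how far each lies from that limit, and whether the group on the nitrogen changes inhibition at all.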